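The source may hold more compounds than are shown below. What is called first, only, known or untested is meant among the compounds shown, and "the series" means these compounds.

Measured compounds in an ADME assay on a cell-free system (plasma, Homo sapiens) for metabolic stability, with Plasma (Rattus norvegicus) as the target, read by HPLC, at pH 7.4; a higher number here means that the compound lasts longer, a lower number that the compound disappears faster:
- compound 1 `CCCCC(=O)O[C@@H]1CO[C@H]2[C@@H]1OC[C@@H]2OC(=O)c1ccccc1OC(C)=O`: 0.0117 h
- compound 2 `CC(=O)Oc1ccccc1C(=O)O[C@H]1CO[C@H]2[C@@H]1OC[C@H]2OC(=O)c1ccccc1`: 0.0107 h
- compound 3 `CC(=O)Oc1ccccc1C(=O)O[C@H]1CO[C@H]2[C@@H]1OC[C@H]2OC(=O)c1ccccc1OC(=O)c1ccccc1`: 0.0722 h

Compound 1 stands second highest of the three numbers in this assay. Its nearest neighbour is compound 2, and the step of a 1.1-fold lower number from compound 1 to compound 2 (0.04 log units; within the scatter) is within the scatter, so the two values cannot be ordered. Compound 3 stands furthest away, with a step beyond the scatter.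

The unmeasured compound 4 `CC(=O)Oc1ccccc1C(=O)O[C@H]1CO[C@H]2[C@@H]1OC[C@H]2OC(=O)c1ccc(-c2ccccc2)cc1` differs from compound 1 by 4-phenylphenyl in place of butyl on a carbonyl carbon. Going by the values given here, two measured steps bear on it. Among the compounds with values here, the step of a 1.1-fold lower number from compound 1 to compound 2 (0.04 log units; within the scatter) is the closest precedent, since it also replaces butyl on the same carbonyl carbon with an aromatic group, and it produced no change beyond the scatter. The step of a 6.7-fold higher number from compound 2 to compound 3 (0.83 log units; beyond the scatter) shows that enlarging an aromatic ester group on the other side of the core can raise the half-life modestly; however, that step adds benzoyloxy on an aromatic carbon, which is a different change from the present one, and it sits on a different ester of the core.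

On this basis only a small rise is expected for compound 4 in this assay, with a step of a 1.7-fold higher number from compound 1 to compound 4 (0.23 log units; within the scatter) that may well stay within the scatter. The estimate for compound 4 is 0.02 h, with a range from 0.008 h to 0.06 h.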

Compound 4, half-life: > 0.333 h
Compound 4: a limit, no number; the forecaster's own chance of this, stated with the estimate: 5%; at least 16-fold (1.22 log units) between middle value and limit.
By their numbers in this assay, from the lowest: compounds 2 and 1 (each within the scatter of the next); then compound 3. At a limit, above all of these: compound 4.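

In this assay, compound 4 reads > 0.333 h, which is a limit of the assay and not a number: the limit of > 0.333 h in this assay, at which 1 of the 4 values shown sits.

On a carbonyl carbon whose other neighbours are oxygen next to a carbonyl group, 4-phenylphenyl in place of butyl gives an at least 28-fold higher number from compound 1 to compound 4 (1.45 log units; beyond the scatter), whereas the smaller phenyl exchange at this place gives a 1.1-fold lower number from compound 1 to compound 2 (0.04 log units; within the scatter), so this position does respond to change, but an aromatic ring alone is not enough. The change from phenyl to 4-phenylphenyl accounts for a step of its own, an at least 31-fold higher number from compound 2 to compound 4 (1.49 log units; beyond the scatter), so among these compounds the large rise at this position appears only with the second aromatic ring.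

The limit leaves the full size of both new steps undetermined, and with a single compound at this limit, no ranking among 4-phenylphenyl analogues can be drawn. Also open, going by these compounds, is whether a longer chain, such as octyl, on the same carbonyl carbon would give a similar rise or whether a carboxylic acid or an amine on the outer ring of the 4-phenylphenyl group would keep it.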